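A few compounds are considered here, and "the series" means these few. Any claim that something is new, unique, unknown or untested is made for them only; others in the source may bear on it.

Measured so far in a functional assay on PC-3 cells (Homo sapiens) for antiproliferative activity, read by MTT assay, with a stated time of 48 h; a lower number here means a stronger inhibitor, a higher number a weaker inhibitor:
- compound 1 `O=C(/C=C\Nc1ccc(F)cc1)c1cn(-c2ccccc2)nc1-c1ccccc1`: 7980 nM
- compound 2 `O=C(/C=C\Nc1ccc(Cl)cc1)c1cn(-c2ccccc2)nc1-c1ccccc1`: 5200 nM
- compound 3 `COc1cc(-c2nn(-c3ccccc3)cc2C(=O)/C=C\Nc2ccc(F)cc2)cc(OC)c1OC`: 7700 nM

Compound 1 and compound 2 share one core and differ only by chloro in place of fluoro on an aromatic carbon; in this assay the change gives a 1.5-fold lower number from compound 1 to compound 2 (0.19 log units; within the scatter), so the two values sit within the usual scatter of each other. Compound 3 carries a different core; the difference between the two cores is not broken down here. Compound 3 and compound 1 give values in this assay that are within the scatter of each other, as are compound 3 and compound 2.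

Compound 4 `COc1cc(-c2nn(-c3ccccc3)cc2C(=O)/C=C\Nc2ccc(Cl)cc2)cc(OC)c1OC` is not yet measured. It stands to compound 3 as compound 2 stands to compound 1: the change is chloro in place of fluoro on an aromatic carbon, and the place of the change reads the same in both pairs, so it is the same change. With only compound 1 and compound 2 as precedent, the step from compound 3 to compound 4 is expected to be small, about a 1.4-fold lower number from compound 3 to compound 4 (0.15 log units; within the scatter), because the earlier pair gave a 1.5-fold lower number from compound 1 to compound 2 (0.19 log units; within the scatter). The value of compound 4 in this assay is therefore estimated at 5500 nM, with a range from 2500 nM to 12000 nM.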

Compound 4, half-maximal inhibitory concentration: 11200 nM
For compound 4 the middle estimate is 2.0-fold (0.31 log units) below the measured one; low and high end bracket the measured number.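

In this assay, chloro in place of fluoro on the core of the trimethoxy-free pair's partner gives a 1.5-fold higher number from compound 3 to compound 4 (0.16 log units; within the scatter), so on this core the exchange stays within the scatter. Set beside the earlier pair, the same change gives steps that do not differ beyond what two such steps can show: the same change on two cores in this assay, a 1.5-fold lower number (0.19 log units; within the scatter) from compound 1 to compound 2 and a 1.5-fold higher number (0.16 log units; within the scatter) from compound 3 to compound 4, 2.2-fold (0.35 log units) apart, within the scatter of two such steps. This shows that, on these two cores, the exchange between the two halogens leaves the number within the scatter and that no dependence on the core can be seen; it does not show that the change is without effect, or that it would behave alike on a third core, as it rests on two pairs only.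

The compounds shown leave open whether a group other than fluoro or chloro on that aromatic carbon, such as a nitrile, an amine or a carboxylic acid, would move the number beyond the scatter. They also leave open whether a hydrogen at that place would give a value in line with these.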